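Swapping 4-bromophenyl for acetamido on a shared core

The source may hold more compounds than are shown below. What is called first, only, known or untested is meant among the compounds shown, and "the series" means these compounds.

Compound 1 `O=C1Nc2ccc(S(=O)(=O)N3CCOCC3)cc2/C1=N/c1ccc(Br)cc1`: 372000 nM
Compound 2 `Cc1ccc(S(=O)(=O)N/N=C2\C(=O)Nc3ccc(S(=O)(=O)N4CCOCC4)cc32)cc1`: 261000 nM
Compound 3 `CC(=O)N/N=C1\C(=O)Nc2ccc(S(=O)(=O)N3CCOCC3)cc21`: not yet measured

Among the compounds with values here, all three compounds are judged in the same test, an ADME assay on WI-38 cells (Homo sapiens) for cytotoxicity, read by sulforhodamine B assay, with a stated time of 24 h (a lower number here means a stronger inhibitor, a higher number a weaker inhibitor), and the two numbers so far sit close together. Compound 1 gives 372000 nM and compound 2 gives 261000 nM and these values lie within the usual scatter of repeated measurements. Within the data shown here, compound 1 therefore cannot be ranked apart from compound 2, even though only two numbers exist.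

The change to follow starts from compound 1 and puts acetamido in place of 4-bromophenyl on a double-bonded nitrogen. The rest of the structure stays as it is. Among the measured compounds shown here, no measured pair here differs in just one place, so no earlier step shows what such a swap does in this assay and any forecast is rough. For the measured compounds named here, with compound 1 at 372000 nM and compound 2 at 261000 nM as the only guides, no shift beyond the scatter is expected, in either direction. The expected change is small, an estimated 1.2-fold lower number from compound 1 to compound 3 (0.09 log units; within the scatter) and no more than that. The estimate for compound 3 is 300000 nM (expected range 130000 nM to 650000 nM).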

Compound 3, half-maximal inhibitory concentration: 325000 nM
Compound 3: middle estimate off by 1.1-fold (0.03 log units), on the low side; the measured number falls inside the stated range.
By their numbers in this assay, from the lowest: compounds 2, 3 and 1 (each within the scatter of the next).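

Within the data shown here, putting acetamido in place of 4-bromophenyl on a double-bonded nitrogen gives a 1.1-fold lower number from compound 1 to compound 3 (0.06 log units; within the scatter) in this assay and this is the first direct reading of a change at this position. An aromatic ring leaves, a group with no ring and with a hydrogen-bond donor and acceptor enters, and yet the two compounds cannot be told apart in this test. The second step, with acetyl in place of (4-methylphenyl)sulfonyl on an amine nitrogen, gives a 1.2-fold higher number from compound 2 to compound 3 (0.10 log units; within the scatter) and so also stays inside the scatter, while nothing measured here explains why these changes leave the number unmoved.

On these data alone, all three compounds share the same core, so what that core itself contributes to the number remains open. It is also unknown whether a carboxylic acid or an amine in place of acetamido on a double-bonded nitrogen would shift the number beyond the scatter, or whether this position would stay as unresponsive as these compounds suggest.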